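This account rests on a few compounds, and the source may have more. Where it says the series, first, only, none or still open, it means among the compounds named here.

Measured so far:
- compound 1 `COc1ncnc2c1c(-c1cc3ccccc3o1)cn2[C@@H]1O[C@H](CO)[C@@H](O)[C@H]1O`: > 20000 nM (a limit of the assay)
- compound 2 `CNc1ncnc2c1c(-c1ccco1)cn2[C@@H]1O[C@H](CO)[C@@H](O)[C@H]1O`: 850 nM

Both values come from a functional assay on HepG2 cells (Homo sapiens) for antiproliferative activity, read by XTT assay, with a stated time of 72 h; on this read-out higher numbers stand for weaker inhibition and lower numbers for stronger inhibition. For the measured compounds named here, compound 2, with 850 nM, holds the only actual number. Compound 1 gives > 20000 nM, which is a limit and not a number.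

The next compound is compound 3 `CNc1ncnc2c1c(-c1cccs1)cn2[C@@H]1O[C@H](CO)[C@@H](O)[C@H]1O`, which carries thiophen-2-yl in place of furan-2-yl on an aromatic carbon of the shared core (thiophen-2-yl in place of furan-2-yl on an aromatic carbon). Going by the values given here, no step between measured compounds in this assay offers a guide to this exchange, so the expectation starts from compound 2 and its 850 nM. No change beyond the scatter is expected, and no direction is favoured. The expected step is a 1.4-fold lower number from compound 2 to compound 3 (0.15 log units; within the scatter). For compound 3 the estimated value is 600 nM, with an expected range of 120 nM to 3500 nM.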

Compound 3, half-maximal inhibitory concentration: > 20000 nM
Compound 3 gave a limit, no number; the forecaster's own chance of this, stated with the estimate: 10%; middle value at least 33-fold (1.52 log units) from the limit.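

In this assay, thiophen-2-yl in place of furan-2-yl on this aromatic carbon is far from a neutral exchange, although the two groups match in heavy atoms, ring size, donors and acceptors: the step is an at least 23-fold higher number from compound 2 to compound 3 (1.37 log units; beyond the scatter) on a single ring atom. Compound 3 gives > 20000 nM in this series, which is a limit and not a number. The step therefore sets only a lower bound, and its full size cannot be read: the limit of > 20000 nM in this assay, at which 2 of the 3 values shown sit.

For the compounds shown here, open is how narrow the tolerance at this carbon is, since only furan-2-yl gives a number in this assay so far. A phenyl ring, an amine or a carboxylic acid on this carbon, with the rest of compound 2 kept, would show whether furan-2-yl is a lone exception.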